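A few compounds are considered here, and "the series" means these few. Any claim that something is new, unique, unknown or untested is made for them only; others in the source may bear on it.

Of the compounds shown here, two of a shared core have been measured in a functional assay on SK-MEL-2 cells (Homo sapiens) for cytotoxicity, read by sulforhodamine B assay, with a stated time of 48 h, tested at 1 uM; a higher number here means a weaker effect of the compound at the concentration tested, a lower number a stronger effect. Compound 1, `COc1cc(C)cc(-c2c(-c3ccnc(-c4ccc(C(C)=O)cc4)c3)cnn2CC#N)c1`, gives 34% in this assay. Compound 2, `Cc1cc(O)cc(-c2nn(CC#N)cc2-c2ccnc(-c3ccc(Oc4ccccc4)cc3)c2)c1`, gives 6% in this assay. Within the data shown here, of the two numbers, the one for compound 2 is the lower, and the number for compound 1 stands well above it, by more than the usual scatter of repeated measurements; the two structures differ in more than one place, so the numbers say nothing about any single change between them.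

Compound 3, `Cc1cc(O)cc(-c2nn(CC#N)cc2-c2ccnc(-c3ccc(N(C)C)cc3)c2)c1`, has not yet been measured. It differs from compound 2 in one place: dimethylamino in place of phenoxy on an aromatic carbon. Among the measured compounds shown here, there is no measured pair in this set that isolates such a change, so the size of the step is open. Compound 2 sits at the strong end of the two numbers, which leaves more room upward than downward, and the account therefore expects an upward step a number 19 percentage points higher from compound 2 to compound 3 (beyond the scatter) in this assay, likely beyond the scatter, though a step within the scatter cannot be ruled out. For compound 3 the estimate in this assay is 25%, with a range from 5% to 60%.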

Compound 3, a percentage reported as activity, at one concentration (the size of the read-out at that concentration, not a potency): 11%
Estimate against measurement, compound 3: 14 percentage points above; the measured number falls inside the stated range.
By their numbers in this assay, from the lowest: compounds 2 and 3 (each within the scatter of the next); then compound 1.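

Among these compounds, exchanging phenoxy for dimethylamino on this aromatic carbon, para to a large group, gives a number 5 percentage points higher from compound 2 to compound 3 (within the scatter) in this assay, the first step in the set that isolates a single change. At this position, and at this one concentration, the two groups cannot be told apart, even though dimethylamino has no ring and fewer heavy atoms than phenoxy, so the six-membered aromatic ring of phenoxy is not required for a low number here, as far as this one replacement shows. The compounds offer no measurement that would explain this result.

Going by these compounds, whether the position accepts any group just as readily remains open: a primary amine, a carboxylic acid or a longer chain such as butoxy could still give a different number from the two seen so far. Also open is what lies behind the higher number of compound 1, which differs from compound 2 in more than one place, so the separate contributions of its acetyl and methoxy groups cannot be read from this set.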